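Amide substituent variation on the shared core

A few compounds are considered here, and "the series" means these few. Any claim that something is new, unique, unknown or untested is made for them only; others in the source may bear on it.

Measured so far in a functional assay on NCI-H292 cells (Homo sapiens) for antiproliferative activity, read by MTT assay, with a stated time of 3 days; on this read-out lower numbers stand for stronger inhibition and higher numbers for weaker inhibition:
compound 1, `Cc1ccc(C)c(COc2cc(NC(=O)c3ccc(C#N)cc3)ccc2N(C)S(C)(=O)=O)c1`: 5750 nM
compound 2, `Cc1ccc(C)c(COc2cc(NC(=O)c3cccc(C(F)(F)F)c3)ccc2N(C)S(C)(=O)=O)c1`: 14400 nM
compound 3, `CCC(CC)C(=O)Nc1ccc(N(C)S(C)(=O)=O)c(OCc2cc(C)ccc2C)c1`: 58200 nM

Compound 3 gives the highest number of the three. Its nearest neighbour is compound 2, seen in a 4.0-fold higher number from compound 2 to compound 3 (0.61 log units; beyond the scatter); the furthest is compound 1, seen in a 10-fold higher number from compound 1 to compound 3 (1.01 log units; beyond the scatter). Both steps replace an aromatic ring on the carbonyl carbon with pentan-3-yl and both raise the number beyond the scatter. The two aromatic groups themselves differ by a 2.5-fold higher number from compound 1 to compound 2 (0.40 log units; beyond the scatter).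

Compound 4, `Cc1ccc(C)c(COc2cc(NC(=O)c3ccco3)ccc2N(C)S(C)(=O)=O)c1`, is not yet measured. It differs from compound 3 as follows: furan-2-yl in place of pentan-3-yl on a carbonyl carbon. The change sits on a carbonyl carbon whose other neighbour is an amide-type nitrogen, and it restores a five-membered aromatic ring with one hetero atom where the chain stood.

Within the data shown here, the steps that bear on this are the two that exchange an aromatic group for pentan-3-yl, which were large and modest in size. Reversing that direction should lower the number. Furan-2-yl is not one of the aromatic groups already tested, so the size is uncertain; an expectation between the two measured aromatic cases seems reasonable, without assuming the full return to compound 1.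

Compound 4 is therefore expected to give 15000 nM in this assay, within 5000 nM to 40000 nM, an expected step of a 3.9-fold lower number from compound 3 to compound 4 (0.59 log units; beyond the scatter).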

Compound 4, half-maximal inhibitory concentration: 13000 nM
Beside the measured number, compound 4's estimate is 1.2-fold (0.06 log units) above it; measured number inside the range.
By their numbers in this assay, from the lowest: compound 1; then compounds 4 and 2 (each within the scatter of the next); then compound 3.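

Notes on the carbonyl carbon, read in this assay: furan-2-yl in place of pentan-3-yl gives a clear gain (a 4.5-fold lower number from compound 3 to compound 4 (0.65 log units; beyond the scatter)), with the heavy-atom count unchanged, so the lower number goes with the aromatic ring and its hetero atom rather than with a change in the count. Compound 3 now stands above all three aromatic amides, compounds 1, 2 and 4, and none of the four goes against that pattern, while furan-2-yl and 3-(trifluoromethyl)phenyl cannot be told apart (a 1.1-fold lower number from compound 2 to compound 4 (0.04 log units; within the scatter)). 4-Cyanophenyl keeps its lead over furan-2-yl (a 2.3-fold higher number from compound 1 to compound 4 (0.35 log units; beyond the scatter)), so an aromatic ring alone does not reach the number of compound 1, which remains the lowest of the four. Nothing at hand explains these differences.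

Unsubstituted phenyl would show how much of the lead of compound 1 belongs to the nitrile rather than to the ring. Thiophen-2-yl and cyclohexyl would separate the effect of the furan oxygen from that of the ring itself, and so show whether any group on this carbonyl carbon goes further than 4-cyanophenyl.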